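The source may hold more compounds than are shown below. What is called first, only, known or untested is meant among the compounds shown, and "the series" means these compounds.

Working notes on the series. Compound 1 `CCCCOc1ccc(-c2nc3ncccn3c2Nc2ccc(F)cc2)cc1` and compound 2 `CCCCOc1ccc(-c2nc3ncccn3c2Nc2ccccc2)cc1` share one core and differ only at the aniline. In a toxicity assay on A549 cells (Homo sapiens) for cytotoxicity, read by luminescence and CellTiter-Glo, with a stated time of 48 h (a lower number here means that less compound is tolerated, a higher number that more compound is tolerated), compound 1 reaches only the limit of the assay, > 100000 nM. Compound 2 gives 100000 nM in this assay, the only number shown so far. The step of a number no higher from compound 1 to compound 2 (the limit leaves the size open) is a number no higher, its size left open by the limit (the limit of > 100000 nM in this assay, at which 1 of the 2 values shown sits).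

Compound 3 `CCCCOc1ccc(-c2nc3ncccn3c2NCc2ccc(OC)cc2)cc1` comes next; the change is 4-methoxybenzyl in place of phenyl on a nitrogen on an aromatic ring. Within the data shown here, no measured step touches this part of the molecule, so nothing here speaks for a move beyond the scatter. The expected step of no change at the digits printed from compound 2 to compound 3 (within the scatter) is therefore none beyond the scatter, and compound 3 is estimated at 100000 nM in this assay, within 40000 nM to 200000 nM, with a fair chance that only a limit is reported.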

Compound 3, half-maximal cytotoxic concentration: 55000 nM
The estimate for compound 3 lay 1.8-fold (0.26 log units) above the measured number; the range from low to high includes it.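

In this assay, among these compounds, the position on the nitrogen on an aromatic ring now carries 4-methoxybenzyl as well as phenyl, which gives the first step at this position with a number at both ends. That step, a 1.8-fold lower number from compound 2 to compound 3 (0.26 log units; within the scatter), stays within the scatter, so this exchange of groups does not separate the two compounds. The second step, an at least 1.8-fold lower number from compound 1 to compound 3 (0.25 log units; that floor lies within the scatter), gives only a floor, and its size stays open because compound 1 sits at a limit: the limit of > 100000 nM in this assay, at which 1 of the 3 values shown sits.

Going by these compounds, what an amine or a carboxylic acid in place of 4-methoxybenzyl would give in this assay remains open, as does whether any group at this position moves the number beyond the scatter. The compounds shown do not vary the rest of the molecule, so the effect of a longer chain there is also open.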